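Piperidine aryl variation on a shared amide core

The source may report more compounds than this note shows. Statements on the series, on what has been measured and on what is new or still open speak of the compounds shown alone.

Measured so far:
compound 1 `O=C1COc2ccc(NC(=O)C3CCN(c4cccc(Br)c4)CC3)cc2N1` — 330 nM
compound 2 `CC(C)c1ccccc1N1CCC(C(=O)Nc2ccc3c(c2)NC(=O)CO3)CC1` — 180 nM

In a functional assay for antagonist activity at transient receptor potential cation channel subfamily V member 1 (Homo sapiens), read by FLIPR and calcium flux (a higher number here means a weaker inhibitor, a lower number a stronger inhibitor), compound 2 gives 180 nM and stands at the lowest of the two numbers; the nearest is compound 1, which gives 330 nM, and the two lie within the scatter of each other, so no order between them is claimed.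

Compound 3 `O=C1COc2ccc(NC(=O)C3CCN(c4cccc(Cl)c4)CC3)cc2N1` is the next case. The change from compound 2 is 3-chlorophenyl in place of 2-isopropylphenyl on an amine nitrogen in a ring. Within the data shown here, one measured step bears on the aryl group on this ring nitrogen: a 1.8-fold lower number from compound 1 to compound 2 (0.26 log units; within the scatter). That step swapped a halogen-bearing phenyl for the isopropyl-bearing one and stayed within the scatter, so the reverse direction, toward another halogen-bearing phenyl, gives no reason to expect a step beyond the scatter in this assay.

Compound 1, with 330 nM, is the closest measured analogue in kind to compound 3, and the expectation leans toward it. Compound 3 is therefore estimated at 350 nM, within 140 nM to 900 nM. The expected step is a 1.9-fold higher number from compound 2 to compound 3 (0.29 log units; within the scatter).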

Compound 3, half-maximal inhibitory concentration: 190 nM
The estimate for compound 3 lay 1.8-fold (0.27 log units) above the measured number; the range from low to high includes it.
By their numbers in this assay, from the lowest: compounds 2, 3 and 1 (each within the scatter of the next).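

In this assay, among these compounds, chloro in place of bromo on an aromatic carbon, a change the earlier compounds did not cover, gives a 1.7-fold lower number from compound 1 to compound 3 (0.24 log units; within the scatter), so the two halogens are not told apart at this aryl group. The change from 2-isopropylphenyl to 3-chlorophenyl on the amine nitrogen in a ring gives a 1.1-fold higher number from compound 2 to compound 3 (0.02 log units; within the scatter), which shows that going from 9 heavy atoms to 7 in this group, with carbon-only substitution giving way to a halogen, leaves the number within the scatter, and all three compounds now lie within the scatter of one another. No measurement at hand bears on why these aryl groups read alike.

The step from compound 2 alters both the substituent and its numbered location on the phenyl, and the compounds shown cannot separate the two. Also open, from the compounds shown here alone, is whether a carboxylic acid, an amine or a longer alkyl chain on this phenyl, or any change to the shared core, would give a step beyond the scatter.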